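Exchanging (diethylamino)methyl for (3-hydroxyazetidin-1-yl)carbonyl

The source may hold more compounds than are shown below. What is called first, only, known or untested is meant among the compounds shown, and "the series" means these compounds.

In a functional assay on HCT-116 cells (Homo sapiens) for inhibition (on this read-out higher numbers stand for an effect only at larger amounts of compound and lower numbers for an effect already at smaller amounts), compound 3 `CCN(CC)CC1CCN(c2ccc(Nc3nc(NC4CCCCC4)c4nc[nH]c4n3)c(OC)c2)CC1` gives 55 nM. This lies within the scatter of compound 2 `COc1cc(N2CCC(CC(=O)N3CCOCC3)CC2)ccc1Nc1nc(NC2CCCCC2)c2nc[nH]c2n1` at 70 nM, while compound 1 `COc1cc(N2CCC(C(=O)N3CCOCC3)CC2)ccc1Nc1nc(NC2CCCCC2)c2nc[nH]c2n1` gives 130 nM. Compound 4 `COc1cc(N2CCC(C(=O)N3CC(O)C3)CC2)ccc1Nc1nc(NC2CCCCC2)c2nc[nH]c2n1` differs from compound 3 by (3-hydroxyazetidin-1-yl)carbonyl in place of (diethylamino)methyl on a saturated ring carbon, with (3-hydroxyazetidin-1-yl)carbonyl in place of (diethylamino)methyl on a saturated ring carbon. The closest guide is a 2.4-fold lower number from compound 1 to compound 3 (0.37 log units; beyond the scatter), a modest step that runs from an amide to (diethylamino)methyl, opposite to the change here. The other two steps, a 1.9-fold lower number from compound 1 to compound 2 (0.27 log units; within the scatter) and a 1.3-fold lower number from compound 2 to compound 3 (0.10 log units; within the scatter), stay within the scatter. No (3-hydroxyazetidin-1-yl)carbonyl compound has been measured yet. A similarly modest move to a higher number is therefore expected, a 2.2-fold higher number from compound 3 to compound 4 (0.34 log units; beyond the scatter). For compound 4 the estimated value is 120 nM, within an expected range of 45 nM to 320 nM.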

Compound 4, half-maximal effective concentration: 260 nM
Beside the measured number, compound 4's estimate is 2.2-fold (0.34 log units) below it, and the stated range covers the measured number.
By their numbers in this assay, from the lowest: compounds 3, 2, 1 and 4 (each within the scatter of the next, the first and the last beyond it).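

In this assay, within the data shown here, (3-hydroxyazetidin-1-yl)carbonyl on this saturated ring carbon gives a larger rise than the earlier steps showed, with a 4.7-fold higher number from compound 3 to compound 4 (0.67 log units; beyond the scatter) against (diethylamino)methyl and a 3.7-fold higher number from compound 2 to compound 4 (0.57 log units; beyond the scatter) against ((morpholin-4-yl)carbonyl)methyl. With the carbonyl kept, 3-hydroxyazetidin-1-yl and morpholin-4-yl are not separated, as a 2.0-fold higher number from compound 1 to compound 4 (0.30 log units; within the scatter) stays within the scatter. Nothing available here accounts for these steps. Still open, on these data alone, is whether an azetidin-1-yl amide without the hydroxyl would differ from compound 4. As far as these compounds go, a carboxylic acid or a piperazine amide at this ring carbon also remains open.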